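Ether Aryl Variation in a Shared Core: Fluoropyridyl Step

The source may hold more compounds than are shown below. What is called first, only, known or untested is meant among the compounds shown, and "the series" means these compounds.

Measured compounds: compound 1 `O=C1c2cc(COc3ccccc3)nn2CCN1c1ccc(F)cc1` 79%; compound 2 `O=C1c2cc(COc3ccccn3)nn2CCN1c1ccc(F)cc1` 68%; compound 3 `O=C1c2cc(COc3cccnc3)nn2CCN1c1ccc(F)cc1` 69%.

All three values come from a functional assay on HEK293 cells for positive allosteric modulation of metabotropic glutamate receptor 5 (Homo sapiens), read by calcium flux; on this read-out lower numbers stand for smaller maximal responses and higher numbers for larger maximal responses. Compound 3 stands within the scatter of both neighbours: a number 1 percentage points higher from compound 2 to compound 3 (within the scatter) and a number 10 percentage points lower from compound 1 to compound 3 (within the scatter). Going by the values given here, only one step is beyond the scatter, a number 11 percentage points lower from compound 1 to compound 2 (beyond the scatter), and even that is modest.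

Compound 4 `O=C1c2cc(COc3ccc(F)cn3)nn2CCN1c1ccc(F)cc1` differs from compound 3 in one place: 5-fluoropyridin-2-yl in place of pyridin-3-yl on an oxygen on a saturated carbon. Among the compounds with values here, two measured steps bear on it. The shift of the ring attachment from pyridin-3-yl to pyridin-2-yl is covered by a number 1 percentage points higher from compound 2 to compound 3 (within the scatter), which is within the scatter. Within the data shown here, the added fluorine has no counterpart among the measured compounds, so its effect is unknown. In this assay a small downward step is therefore expected, likely within the scatter, because compound 2 gives 68%. The expected step is a number 3 percentage points lower from compound 3 to compound 4 (within the scatter). Compound 4 is estimated at 66%, with a range from 54% to 78%.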

Compound 4, largest response reached (Emax), in percent of the reference or control that the assay uses: 52%
Compound 4: the middle estimate sits 14 percentage points above what was measured; the measured number lies below the stated range.
By their numbers in this assay, from the lowest: compound 4; then compounds 2, 3 and 1 (each within the scatter of the next, the first and the last beyond it).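

In this assay the fluoro in place of hydrogen on an aromatic carbon gives a number 16 percentage points lower from compound 2 to compound 4 (beyond the scatter) and so shows that this aryl ether is sensitive to one added fluorine, which compounds 1, 2 and 3 could not reveal, as they differ only in phenyl, pyridin-2-yl or pyridin-3-yl on the oxygen. The same separation appears as a number 17 percentage points lower from compound 3 to compound 4 (beyond the scatter) and, against the phenyl ether, as a number 27 percentage points lower from compound 1 to compound 4 (beyond the scatter) as the largest step in the set. Nothing measured here explains why the added fluorine goes with a smaller maximal response.

As far as these compounds go, whether the step belongs to fluorine itself or to any added group on this ring stays open. A chloro, methyl or methoxy group in its place could separate the two, and a fluoro on the phenyl ring of compound 1 would show whether the step carries over to that ether.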